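The compounds below may be only part of what the source reports. "The series", "measured", "known", "first", "only" and "open" are said of these compounds alone.

Compound 1 `O=C(N/N=C/c1ccccc1)c1cccnc1` is the starting point of this comparison. In an ADME assay on HEL cells (Homo sapiens) for cytotoxicity, read by microscopy (on this read-out lower numbers stand for higher toxicity in this test and higher numbers for lower toxicity in this test), compound 1 gives > 100 ug/mL, which is a limit of the test and not a measured number. Two measured neighbours share its core. Compound 2 `O=C(N/N=C/c1ccc(Cl)cc1)c1cccnc1` carries chloro in place of hydrogen on an aromatic carbon; in this assay compound 2 gives > 100 ug/mL, again only a limit. Compound 3 `O=C(N/N=C/c1ccccc1[N+](=O)[O-])c1cccnc1` carries nitro in place of hydrogen on an aromatic carbon; in this assay compound 3 gives > 100 ug/mL, also a limit. Among the compounds with values here, the two steps recorded so far, a step that the two limits leave unreadable from compound 1 to compound 2 and a step that the two limits leave unreadable from compound 1 to compound 3, therefore cannot be sized, because the limit of > 100 ug/mL in this assay, at which 3 of the 3 values shown sit, holds every value so far.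

The compound not yet measured is compound 4 `O=C(N/N=C/c1cccc(O)c1)c1cccnc1`. It differs from compound 1 by hydroxy in place of hydrogen on an aromatic carbon. Within the data shown here, no measured step in this set bears on a hydroxy group, and the steps that exist are unreadable, so the only guide is that all three known compounds sit at the same limit. The step from compound 1 to compound 4 is therefore expected to be none beyond the scatter, a number no higher from compound 1 to compound 4 (the limit leaves the size open). Compound 4 is expected to give about 100 ug/mL in this assay, within a range from 50 ug/mL to 200 ug/mL, most probably reported once more only as a limit.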

Compound 4, minimum cytotoxic concentration: > 100 ug/mL
Compound 4 gave a limit, no number; the forecaster's own chance of this, stated with the estimate: 85%; the middle value lies on the limit itself.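

The step from compound 1 to compound 4 cannot be read in this assay, because both compounds give only a limit of the test and no measured number: the limit of > 100 ug/mL in this assay, at which 4 of the 4 values shown sit.

The compounds shown leave open whether chloro, nitro or hydroxy in place of hydrogen on an aromatic carbon changes the toxicity of the shared core in this assay at all.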